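Compound 3: cyclohexyl in place of 4-chlorophenyl

The source may report more compounds than this note shows. Statements on the series, on what has been measured and on what is new or still open speak of the compounds shown alone.

Two compounds on the shared core serve as reference points: compound 1 `COc1cc2ncnc(-n3nc(-c4ccncc4)nc3N)c2cc1OC` and compound 2 `COc1cc2ncnc(-n3nc(-c4ccc(Cl)cc4)nc3N)c2cc1OC`. In an ADME assay on BJ cells (Homo sapiens) for cytotoxicity, with a stated time of 72 h (on this read-out higher numbers stand for an effect only at larger amounts of compound and lower numbers for an effect already at smaller amounts), compound 1 has the entry "not determined" (no result reported), so it offers no comparison. In this assay compound 2 gives > 50000 nM, which is a limit of the assay and not a number. Among the measured compounds shown here, no measured step between two compounds is available to size a change.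

Compound 3 `COc1cc2ncnc(-n3nc(C4CCCCC4)nc3N)c2cc1OC` carries cyclohexyl in place of 4-chlorophenyl on an aromatic carbon of the five-membered aromatic ring with 3 nitrogen, two ring bonds from the ring atom that bears an amino group (cyclohexyl in place of 4-chlorophenyl on an aromatic carbon). No shift beyond the usual scatter is expected in this assay, in either direction. This expectation rests on compound 2 alone, whose only anchor is the limit of > 50000 nM in this assay, at which 1 of the 2 values shown sits. The expected step of a number no higher from compound 2 to compound 3 (the limit leaves the size open) is therefore small, and another report as a limit is the likeliest outcome. For compound 3 the estimate is 50000 nM, with an expected range of 25000 nM to 100000 nM.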

Compound 3, half-maximal effective concentration: > 27000 nM
Compound 3 was reported as a limit; the forecaster's own chance of this, stated with the estimate: 75%; the middle value does not contradict the limit.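

In this assay compound 3 gives > 27000 nM, a limit of the assay and not a number. Compound 2 also stands at a limit, > 50000 nM. Among the compounds shown here, with limits on both sides, no step between compound 2 and compound 3 can be read. The compounds shown leave open whether cyclohexyl and 4-chlorophenyl differ on this read-out.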